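This account rests on a few compounds, and the source may have more. Where it says the series, first, only, none or still open, it means among the compounds named here.

Compound 1 `CC(C)=CCC/C(C)=C/COc1cc(=O)n(CCCO)c2c1CC(CC=C(C)C)C(C)(C)C2` is the reference point of this set. Among the measured compounds shown here, in a functional assay on PANC-1 cells (Homo sapiens) for inhibition, read by MTT assay, with a stated time of 24 h, tested at 10 uM (on this read-out higher numbers stand for more inhibition at the one concentration tested (going by the name of the read-out) and lower numbers for less inhibition), compound 1 gives 18.4%, the highest of the three numbers measured so far. Compound 2 `CC(C)=CCC1Cc2c(OCCCNS(=O)(=O)c3ccc(C(F)(F)F)cc3)cc(=O)n(CCCO)c2CC1(C)C` gives 0% in this assay, and compound 3 `CC(C)=CCC1Cc2c(OCCCOc3ccc([N+](=O)[O-])cc3)cc(=O)n(CCCO)c2CC1(C)C` gives 0%. For the measured compounds named here, the one step that is measured in a single place runs a number 18.4 percentage points lower from compound 1 to compound 3 (beyond the scatter), that is, exchanging the chain on the oxygen on the aromatic ring for an aryl-bearing chain removes the inhibition seen for compound 1 altogether. Compound 2 carries a sulfonamide-bearing chain at the same oxygen and its value likewise sits at zero, so both measured neighbours point the same way.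

Compound 4 `CC(C)=CCC1Cc2c(OC(=O)Nc3ccc(Cl)c(Cl)c3)cc(=O)n(CCCO)c2CC1(C)C` has not yet been measured. It differs from compound 1 as follows: (3,4-dichlorophenyl)carbamoyl in place of 3,7-dimethylocta-2,6-dien-1-yl on an oxygen on an aromatic ring. Going by the values given here, this is again a replacement at the oxygen on the aromatic ring, so the step from compound 1 to compound 3 is the only measured step that bears on it, and it was a modest loss beyond the scatter. A drop of similar size is therefore expected in this assay, a number 14.4 percentage points lower from compound 1 to compound 4 (beyond the scatter). For compound 4 the estimate is 4%, with a range from 0% to 16%.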

Compound 4, a percentage reported as inhibition, at one concentration (the size of the read-out at that concentration, not a potency): 1.8%
For compound 4 the middle estimate is 2.2 percentage points above the measured one; the range from low to high includes it.
By their numbers in this assay, from the lowest: compounds 2, 3 and 4 (each within the scatter of the next); then compound 1.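

At the oxygen on an aromatic ring, the step of a number 16.6 percentage points lower from compound 1 to compound 4 (beyond the scatter) in this assay shows that the low reading is not confined to ether-linked replacements: the (3,4-dichlorophenyl)carbamoyl group attaches through a carbonyl and adds a hydrogen-bond donor, yet compound 4 and compound 3 lie within the scatter of each other. Among the two listed steps at this oxygen, both replacements bring a six-membered aromatic ring in place of the ringless 3,7-dimethylocta-2,6-dien-1-yl chain and both read lower, with no exception so far; that link rests on these compounds alone, and compound 1 itself gives only 18.4%, which leaves little room to separate the replacements from one another. No measurement here explains the loss at this oxygen.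

The compounds shown leave open whether a ringless group at this oxygen, such as a shorter alkyl chain, an amine-bearing chain or a carboxylic acid-bearing chain, would keep a reading near that of compound 1. On these data alone, it also remains open whether a carbamoyl carrying a simple alkyl group instead of the dichlorophenyl ring would read any differently from compound 4.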